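Notes on methyl for oxetan-3-yl: microsomal stability

The compounds below may be only part of what the source reports. "The series", "measured", "known", "first", "only" and "open" are said of these compounds alone.

Measured so far:
- compound 1 `CN(C[C@H]1Cc2c(cccc2N2CCN(C3COC3)CC2)CN1)[C@H]1CCCc2cccnc21`: 50.8%
- compound 2 `FC1(F)CCC(CN(C[C@H]2Cc3c(cccc3N3CCNCC3)CN2)[C@H]2CCCc3cccnc32)CC1`: 76.6%

In an ADME assay on microsomes from liver (Mus musculus) for metabolic stability, read by LC-MS, with a stated time of 10 min (a lower number here means that less of the compound is left, a higher number that more of the compound is left), compound 1 gives 50.8%, the lowest of the two numbers. The nearest number is that of compound 2, which in this assay gives 76.6%, a gap beyond the scatter. Among the measured compounds shown here, the two compounds differ in more than one place, so no single step connects them and their two values are all that can be said.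

Compound 3 `CN1CCN(c2cccc3c2C[C@H](CN(C)[C@H]2CCCc4cccnc42)NC3)CC1` is not yet measured in this assay. Compared with compound 1 the change is methyl in place of oxetan-3-yl on an amine nitrogen in a ring. Put one bond further out, it reads 4-(oxetan-3-yl)piperazin-1-yl to 4-methylpiperazin-1-yl.

For the measured compounds named here, no measured pair shows this change, so there is no step to lean on. The expectation is therefore a step of a number 0.8 percentage points lower from compound 1 to compound 3 (within the scatter), that is, none beyond the scatter, with the value kept near that of compound 1. Compound 3 is thus estimated at 50%, within a range from 30% to 70%.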

Compound 3, percent of the compound remaining: 17%
Beside the measured number, compound 3's estimate is 33 percentage points above it, and the stated range ends above it.
By their numbers in this assay, from the lowest: compound 3; then compound 1; then compound 2.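

Methyl in place of oxetan-3-yl on an amine nitrogen in a ring gives, in this assay, a number 33.8 percentage points lower from compound 1 to compound 3 (beyond the scatter), so this position of the series is not indifferent to the group it carries. The two compounds differ in this one place only, which ties a large step to 4-(oxetan-3-yl)piperazin-1-yl giving way to 4-methylpiperazin-1-yl, with the rest of the core of compound 1 unchanged. Nothing available bears on why the value moves with this change.

Still open, as far as these compounds go, is whether the higher value belongs to oxetan-3-yl itself or would also come with another group on this nitrogen, such as cyclobutyl, acetyl or a 2-hydroxyethyl chain, and which of compound 1 and compound 3 each of these would sit closer to. From the compounds shown here alone, compound 2 differs from both in more than one place, so it does not settle this, and whether the same step holds on a core carrying other substituents also remains open.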